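Phenyl for ethyl on the triazole nitrogen: an expected step

The compounds below may be only part of what the source reports. "The series", "measured", "known", "first", "only" and "open" are said of these compounds alone.

Measured compounds:
compound 1, `COc1ccc(-c2nnc(SCC(=O)Nc3ccc(C(C)=O)cc3)n2-c2ccccc2)cc1`, 58%
compound 2, `COc1cc(-c2nnc(SCC(=O)Nc3ccc(C(C)=O)cc3)n2-c2ccccc2)cc(OC)c1OC`, 55%
compound 3, `CCn1c(SCC(=O)Nc2ccc(C(C)=O)cc2)nnc1-c1ccccc1`, 56%

In a functional assay on the whole organism (strain albino) for inhibition, with Rattus norvegicus as the target, read by paw edema, with stated times of 30 min and 3 h, at a dose of 0.28 mmol/kg by the oral route (on this read-out lower numbers stand for less inhibition and higher numbers for more inhibition at the one dose given (going by the name of the read-out)), compound 3 gives 56%, the second highest of the three numbers. Its nearest neighbour is compound 2, and the furthest is compound 1; both gaps lie within the scatter, so the three measured compounds cannot be told apart on this read-out. Within the data shown here, the only step between compounds that differ in one place is a number 3 percentage points lower from compound 1 to compound 2 (within the scatter), a change on an aromatic carbon that also stays within the scatter.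

Compound 4, `CC(=O)c1ccc(NC(=O)CSc2nnc(-c3ccccc3)n2-c2ccccc2)cc1`, has not been measured. It differs from compound 3 by phenyl in place of ethyl on an aromatic nitrogen, on an aromatic nitrogen of a five-membered aromatic ring with 3 nitrogen. Among the measured compounds shown here, no measured step touches this position, so the step from compound 1 to compound 2 bears on it only indirectly: it shows that a change on the aryl group attached to the ring did not move the number. Compounds 1 and 2 already carry a phenyl on that nitrogen and give numbers close to compound 3, which carries ethyl. Compound 4 is therefore expected to give 56%, in a range from 46% to 66%, and the expected step of no change at the digits printed from compound 3 to compound 4 (within the scatter) is estimated not to exceed the scatter.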

Compound 4, a percentage reported as inhibition, in the whole organism at one dose (the size of the read-out at that dose, not a potency): 62%
Beside the measured number, compound 4's estimate is 6 percentage points below it, within the range that was stated.
By their numbers in this assay, from the lowest: compounds 2, 3, 1 and 4 (each within the scatter of the next).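

In this assay, the change on the aromatic nitrogen now has a direct reading: with phenyl in place of ethyl there, the result is a number 6 percentage points higher from compound 3 to compound 4 (within the scatter), so this swap to a larger ring-bearing group gives a step that stays inside the usual variation. The aryl group on the aromatic carbon also gains its bare phenyl member, with hydrogen in place of methoxy giving a number 4 percentage points higher from compound 1 to compound 4 (within the scatter) and phenyl in place of 3,4,5-trimethoxyphenyl giving a number 7 percentage points higher from compound 2 to compound 4 (within the scatter), so the plain phenyl, 4-methoxyphenyl and 3,4,5-trimethoxyphenyl groups cannot be told apart on this read-out. No experimental evidence is available to explain these results.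

The compounds shown leave open whether a longer chain, a benzyl group or a group carrying an amine on the aromatic nitrogen would also stay within the scatter of these numbers. Going by these compounds, all four compounds keep the same acetyl-bearing remainder of the structure, so the effect of replacing that acetyl group with a carboxylic acid or a nitrile also remains open.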